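Weak cytotoxic amides: swapping the amide-nitrogen aryl group

The compounds below may be only part of what the source reports. "The series", "measured", "known", "first", "only" and "open" are said of these compounds alone.

Measured compounds:
compound 1 `C=CC1=C(C(=O)O)C(c2ccc(F)cc2)OC1` – > 100000 nM
compound 2 `C=CC1=C(C(=O)Nc2ccccc2OC)C(c2ccc(F)cc2)OC1` – 52800 nM
compound 3 `C=CC1=C(C(=O)Nc2ccccc2OC)C(c2ccc(Cl)c(Cl)c2)OC1` – > 100000 nM

Within the data shown here, in a functional assay on QGY7701 cells (Homo sapiens) for cytotoxicity, read by MTT assay, with a stated time of 24 h (on this read-out lower numbers stand for stronger inhibition and higher numbers for weaker inhibition), compound 2 gives 52800 nM, the only outright number among the three; the other two values are limits of the assay, and for compound 1 the value > 100000 nM is such a limit, as is > 100000 nM for compound 3 (the limit of > 100000 nM in this assay, at which 2 of the 3 values shown sit). Compound 4 `C=CC1=C(C(=O)Nc2ccc(C)cc2)C(c2ccc(F)cc2)OC1` differs from compound 2 by 4-methylphenyl in place of 2-methoxyphenyl on an amide-type nitrogen. Among the measured compounds shown here, the only measured step, an at least 1.8-fold higher number from compound 2 to compound 3 (0.27 log units; that floor lies within the scatter), concerns the aryl group on the saturated ring carbon, not the amide nitrogen, so nothing measured bears directly on this change. Compound 4 is therefore expected to stay near compound 2, with a 1.1-fold higher number from compound 2 to compound 4 (0.06 log units; within the scatter) inside the scatter; its estimated value is 60000 nM, between 20000 nM and 150000 nM.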

Compound 4, half-maximal inhibitory concentration: 59200 nM
Estimate against measurement, compound 4: 1.0-fold (0.01 log units) above, and the stated range covers the measured number.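

In this assay, the aryl group on the amide-type nitrogen changes from 2-methoxyphenyl to 4-methylphenyl with no readable effect, giving a 1.1-fold higher number from compound 2 to compound 4 (0.05 log units; within the scatter). The oxygen of the group that leaves is therefore not needed to hold this weak level. Replacing hydroxy on the carbonyl carbon with (4-methylphenyl)amino gives an at least 1.6-fold lower number from compound 1 to compound 4 (0.22 log units; that floor lies within the scatter), so the gain from that change stays unproven, as this comparison rests on a limit: the limit of > 100000 nM in this assay, at which 2 of the 4 values shown sit.

Going by these compounds, it remains open whether a longer alkyl chain on the amide-type nitrogen in place of the aryl group would shift the number. The same holds for an amine on that aryl ring.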